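The compounds below may be only part of what the source reports. "The series", "measured", "known", "first", "only" and "open" are said of these compounds alone.

Measured in a functional assay on L1210 cells (Mus musculus) for antiproliferative activity; on this read-out higher numbers stand for weaker inhibition and lower numbers for stronger inhibition:
- compound 1 `COc1ccc(-c2cc(N)c(C(=O)c3cc(OC)c(OC)c(OC)c3)s2)cc1OC` gives 40 nM
- compound 2 `COc1cc(C(=O)c2sc(-c3ccc([N+](=O)[O-])cc3)cc2N)cc(OC)c1OC` gives 100 nM
- compound 3 `COc1cc(C(=O)c2sc(-c3ccccc3)cc2N)cc(OC)c1OC` gives 11 nM

Compound 3 has the lowest number of the three and is the most potent so far. The next compound, compound 4 `COc1cc(C(=O)c2sc(-c3ccccc3Cl)cc2N)cc(OC)c1OC`, carries chloro in place of hydrogen on an aromatic carbon, ortho to a large group: chloro in place of hydrogen on an aromatic carbon.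

The measured steps that bear on this all change the same aryl group. The closest is the single replacement of nitro by hydrogen, a 9.1-fold lower number from compound 2 to compound 3 (0.96 log units; beyond the scatter). The step of a 3.6-fold lower number from compound 1 to compound 3 (0.56 log units; beyond the scatter) points the same way, while a 2.5-fold higher number from compound 1 to compound 2 (0.40 log units; beyond the scatter) shows that the size of the change depends on the group. In these data, both substituted compounds sit above the unsubstituted compound 3 . Going by the values given here, no chloro compound has been measured, and nothing has been measured at this place on the ring, so the transfer is loose.

A modest rise is expected in this assay, and the estimated change is a 2.7-fold higher number from compound 3 to compound 4 (0.44 log units; beyond the scatter). For compound 4 the expected value is 30 nM, with an estimated range from 9 nM to 120 nM.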

Compound 4, half-maximal inhibitory concentration: 20 nM
Beside the measured number, compound 4's estimate is 1.5-fold (0.18 log units) above it, and the stated range covers the measured number.
By their numbers in this assay, from the lowest: compounds 3, 4 and 1 (each within the scatter of the next, the first and the last beyond it); then compound 2.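

In this assay, chloro in place of hydrogen on an aromatic carbon, ortho to a large group, gives a 1.8-fold higher number from compound 3 to compound 4 (0.26 log units; within the scatter), so this position accepts chloro without a step that can be told from the scatter, unlike the two other substituted aryl groups when set against phenyl. Set against those two groups, the 2-chlorophenyl compound gives a 5.0-fold lower number from compound 2 to compound 4 (0.70 log units; beyond the scatter) and a 2.0-fold lower number from compound 1 to compound 4 (0.30 log units; within the scatter), so it is clearly separated only from the nitro compound. No measurement on hand explains these numbers.

On these data alone, what fluoro, methyl or an amine would give at this same place stays open, and so does the effect of chloro elsewhere on this ring. A carboxylic acid on the ring is likewise an open case for this series.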